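Morpholine for Piperidine on a Thiocarbonyl Carbon

This account rests on a few compounds, and the source may have more. Where it says the series, first, only, none or still open, it means among the compounds named here.

Compound 2 `COc1ccc2occ(CSC(=S)N3CCCCC3)c(=O)c2c1` and compound 3 `CCOC(=O)c1cc(=O)c2cc(CSC(=S)N3CCCCC3)ccc2o1` carry the same piperidin-1-yl on a thiocarbonyl carbon but sit on different cores; the difference between the two cores is not broken down here. In a functional assay on LM7 cells (Homo sapiens) for antiproliferative activity, read by MTT assay, with a stated time of 72 h (on this read-out lower numbers stand for stronger inhibition and higher numbers for weaker inhibition), compound 2 gives 4700 nM. In this assay compound 3 gives 16900 nM, the higher of the two numbers. Compound 1 `COc1ccc2occ(CSC(=S)N3CCOCC3)c(=O)c2c1` is the morpholin-4-yl counterpart of compound 2. Compound 1 reaches only the limit of this assay and gives > 40000 nM, which is a limit rather than a number. The step of an at least 8.5-fold higher number from compound 2 to compound 1 (0.92 log units; beyond the scatter) follows the change (morpholin-4-yl in place of piperidin-1-yl on a thiocarbonyl carbon), and its size is bounded by the limit of > 40000 nM in this assay, at which 1 of the 3 values shown sits.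

Compound 4 `CCOC(=O)c1cc(=O)c2cc(CSC(=S)N3CCOCC3)ccc2o1` has not been measured. It stands to compound 3 as compound 1 stands to compound 2: the change is morpholin-4-yl in place of piperidin-1-yl on a thiocarbonyl carbon, the same change at the same place. If it acts on the core of compound 3 as it did on the core of compound 2, the number for compound 4 should rise well above that of compound 3, which already sits above compound 2, so a limit rather than a number is the likelier outcome in this assay. On that basis compound 4 is expected to give 80000 nM in this assay, between 30000 nM and 250000 nM. The step this expectation implies, a 4.7-fold higher number from compound 3 to compound 4 (0.68 log units; beyond the scatter), rests on compound 2 and compound 1 and their step of an at least 8.5-fold higher number from compound 2 to compound 1 (0.92 log units; beyond the scatter).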

Compound 4, half-maximal inhibitory concentration: > 25000 nM
Compound 4 gave a limit, no number; the forecaster's own chance of this, stated with the estimate: 70%; the middle value is on the limit's open side.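

In this assay compound 4 gives > 25000 nM, which is a limit and not a number. Morpholin-4-yl in place of piperidin-1-yl on a thiocarbonyl carbon therefore leaves both morpholin-4-yl compounds at a limit, but on the core of compound 3 the change can be read only as an at least 1.4-fold higher number from compound 3 to compound 4 (0.17 log units; that floor lies within the scatter), so this core alone does not establish a real rise in the number, and the result shows agreement with the earlier core without showing that the change carries over to the same extent. Set side by side, the two steps cannot be ranked, and nothing shown says whether the core alters the size of the change: the same change on two cores in this assay, an at least 8.5-fold higher number (0.92 log units; beyond the scatter) from compound 2 to compound 1 and an at least 1.4-fold higher number (0.17 log units; that floor lies within the scatter) from compound 3 to compound 4; the limit leaves it open whether they differ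

The compounds shown carry only piperidin-1-yl and morpholin-4-yl on the thiocarbonyl carbon, so they leave open how a pyrrolidin-1-yl, a piperazin-1-yl or an open-chain diethylamino group would read there on either core. They also leave open whether the change would read the same way on a core carrying a carboxylic acid in place of the ethyl ester of compound 3.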